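Cytotoxicity notes: amide versus urea linkers on a shared core

The source may report more compounds than this note shows. Statements on the series, on what has been measured and on what is new or still open speak of the compounds shown alone.

Measured compounds:
compound 1 `COc1cc(-c2nn(-c3cccc(NC(=O)Nc4cc(C(F)(F)F)cc(C(F)(F)F)c4)c3)cc2-c2ccncc2)ccc1Cl` — 4310 nM
compound 2 `COc1cc(-c2nn(-c3cccc(NC(=O)c4cccc(C(F)(F)F)c4)c3)cc2-c2ccncc2)ccc1Cl` — > 50000 nM

Two compounds share the core of compound 1 and differ only in the group attached to the carbonyl carbon. In a functional assay on 786-0 cells (Homo sapiens) for inhibition, read by sulforhodamine B assay, with a stated time of 48 h (a higher number here means that more compound is tolerated, a lower number that less compound is tolerated), compound 1, carrying the urea, gives 4310 nM. For compound 2, the amide, this assay reports only a limit, > 50000 nM, so no number is known for it; this is the limit of > 50000 nM in this assay, at which 1 of the 2 values shown sits. Compound 2 therefore stands at the upper edge of what this assay reports, while compound 1 sits well inside the measurable range.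

Compound 3 `COc1cc(-c2nn(-c3cccc(NC(=O)Nc4ccc(Cl)c(C(F)(F)F)c4)c3)cc2-c2ccncc2)ccc1Cl` is not yet measured. It differs from compound 2 by (4-chloro-3-(trifluoromethyl)phenyl)amino in place of 3-(trifluoromethyl)phenyl on a carbonyl carbon. This turns the amide of compound 2 into a urea of the kind seen in compound 1.

Within the data shown here, no measured step between compounds that differ in a single place exists here, so the expectation rests on the two values shown. A step toward a lower number, beyond the scatter, is expected from compound 2 to compound 3, of size an at least 10-fold lower number from compound 2 to compound 3 (1.00 log units; beyond the scatter). Compound 3 is expected to give about 5000 nM in this assay, within 1500 nM to 20000 nM.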

Compound 3, concentration lethal to 50% of the cells: > 32500 nM
Compound 3: a limit, no number; the forecaster's own chance of this, stated with the estimate: 15%; middle value at least 6.5-fold (0.81 log units) away from the limit.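

In this assay compound 2 gives only a limit, > 50000 nM. Compound 3 also gives only a limit, > 32500 nM. Among these compounds, these two limits allow no step to be read between compound 2 and compound 3. The compounds shown leave open whether (4-chloro-3-(trifluoromethyl)phenyl)amino in place of 3-(trifluoromethyl)phenyl on a carbonyl carbon changes the read-out at all.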